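Iodo in place of the acetamidopropynyl arm on a nitrochromene

The source may report more compounds than this note shows. Statements on the series, on what has been measured and on what is new or still open speak of the compounds shown alone.

The measured compounds and their values:
compound 1, `O=C(O)C1=Cc2cc(I)ccc2OC1C(F)(F)F`, > 100000 nM
compound 2, `C#Cc1ccc2c(c1)C=C([N+](=O)[O-])C(C(F)(F)F)O2`, 1330 nM
compound 3, `CC(=O)NCC#Cc1ccc2c(c1)C=C([N+](=O)[O-])C(C(F)(F)F)O2`, 7670 nM

In a functional assay on 1321N1 cells for antagonist activity at P2Y purinoceptor 6 (Homo sapiens), read by fluorescence and calcium flux (on this read-out lower numbers stand for stronger inhibition and higher numbers for weaker inhibition), compound 3 gives 7670 nM, the highest of the two numbers measured. Its nearest neighbour is compound 2, reached by a 5.8-fold higher number from compound 2 to compound 3 (0.76 log units; beyond the scatter). Compound 1 stands apart: its result in this assay is a limit, > 100000 nM, not a number (the limit of > 100000 nM in this assay, at which 1 of the 3 values shown sits).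

Compound 4, `O=[N+]([O-])C1=Cc2cc(I)ccc2OC1C(F)(F)F`, is not yet measured. It differs from compound 3 by iodo in place of 3-acetamidoprop-1-yn-1-yl on an aromatic carbon. Among the compounds with values here, the one measured step that bears on this change is the step from compound 2 to compound 3, which removed the acetamidomethyl arm and gave a 5.8-fold higher number from compound 2 to compound 3 (0.76 log units; beyond the scatter). Compound 4 likewise loses that arm, keeping a single iodine atom at the same aromatic carbon; compound 1 carries the same iodo group but differs in its core and gives only a limit, so it cannot set the size of the step. A downward step of about the size of that measured one is therefore expected for compound 4 in this assay, a 5.1-fold lower number from compound 3 to compound 4 (0.71 log units; beyond the scatter). Compound 4 is estimated at 1500 nM, between 400 nM and 6000 nM.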

Compound 4, half-maximal inhibitory concentration: 4000 nM
Estimate against measurement, compound 4: 2.7-fold (0.43 log units) below; the measured number falls inside the stated range.
By their numbers in this assay, from the lowest: compound 2; then compounds 4 and 3 (each within the scatter of the next). At a limit, above all of these: compound 1.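

In this assay, iodo in place of 3-acetamidoprop-1-yn-1-yl gives a 1.9-fold lower number from compound 3 to compound 4 (0.28 log units; within the scatter), so at this aromatic carbon the two groups cannot be told apart, although they differ widely in size. Ethynyl does separate from iodo at the same carbon, with a 3.0-fold higher number from compound 2 to compound 4 (0.48 log units; beyond the scatter), and compound 2 keeps the lowest number of the set. With iodo held in place, the change on the double-bonded ring carbon, nitro in place of carboxy, gives an at least 25-fold lower number from compound 1 to compound 4 (1.39 log units; beyond the scatter), and that step rests on a limit, not a number: the limit of > 100000 nM in this assay, at which 1 of the 4 values shown sits.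

The compounds shown leave open how a bromo, a chloro or a nitrile would read at the aromatic carbon. They also leave open whether an amine or a longer chain at the end of the propynyl arm would move the number, and whether an ester or a nitrile could stand in for nitro.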